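This account rests on a few compounds, and the source may have more. Where it says the series, first, only, none or still open, it means among the compounds named here.

Measured so far in a functional assay on HeLa cells (Homo sapiens) for cytotoxicity, read by MTT assay, with a stated time of 72 h; on this read-out lower numbers stand for an effect already at smaller amounts and higher numbers for an effect only at larger amounts of compound:
compound 1 `CCS[C@@H]1[C@H](SCC)[C@@H](Cn2cc(-c3cccc(C)c3)nn2)O[C@H]1n1ccc(=O)[nH]c1=O`: 18800 nM
compound 2 `CCOC(=O)c1cn(C[C@H]2O[C@@H](n3ccc(=O)[nH]c3=O)[C@H](SCC)[C@@H]2SCC)nn1`: >= 100000 nM

Compound 2 sits at the ceiling of this assay, the limit described by the limit of >= 100000 nM in this assay, at which 1 of the 2 values shown sits; its value is a limit and not a number. Among the two measured compounds it stands at the weak end. Among the measured compounds shown here, the one measured step, an at least 5.3-fold higher number from compound 1 to compound 2 (0.72 log units; beyond the scatter), ends at this limit, so all that is known is that 3-methylphenyl outperforms ethoxycarbonyl on that aromatic carbon.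

Compound 3 `CCS[C@@H]1[C@H](SCC)[C@@H](Cn2cc(COC(C)=O)nn2)O[C@H]1n1ccc(=O)[nH]c1=O` is the next member, still unmeasured. It differs from compound 2 in one place: acetoxymethyl in place of ethoxycarbonyl on an aromatic carbon. For the measured compounds named here, no measured step covers this change; the step already seen touches the same position but exchanges a different pair of groups and gives no direction for trading ethoxycarbonyl for acetoxymethyl. With compound 2 at a limit, a step beyond the scatter in either direction cannot be read from the present numbers. Compound 3 is therefore expected near the same limit, a number no higher from compound 2 to compound 3 (the limit leaves the size open), with an estimate of 100000 nM and a range from 30000 nM to 300000 nM.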

Compound 3, half-maximal effective concentration: >= 100000 nM
Compound 3: only a limit was reported; the forecaster's own chance of this, stated with the estimate: 65%; the middle value lies on the limit itself.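

Compound 3, like compound 2, is reported in this assay only as a limit: the limit of >= 100000 nM in this assay, at which 2 of the 3 values shown sit.

Acetoxymethyl in place of 3-methylphenyl gives an at least 5.3-fold higher number from compound 1 to compound 3 (0.72 log units; beyond the scatter), so two different ester-bearing groups on this aromatic carbon now fall short of 3-methylphenyl. The step between compound 2 and compound 3 cannot be read, since both values are limits, and the same atoms joined differently therefore give no order between ethoxycarbonyl and acetoxymethyl.

Among the compounds shown here, compound 1 remains the only compound of the three with a number, so it stays open whether the aromatic ring of 3-methylphenyl or its methyl group carries the difference. Also open, as far as these compounds go, is how a plain phenyl, an aminomethyl or a carboxylic acid on this carbon would read in this assay.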